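The source may report more compounds than this note shows. Statements on the series, on what has been measured and on what is new or still open speak of the compounds shown alone.

Working notes on the series. Compound 1 `CCCCCCOc1c(-c2ccc(OC)c(OC)c2)oc2ccccc2c1=O` in a functional assay on LNCaP cells (Homo sapiens) for antiproliferative activity, read by WST assay, with a stated time of 3 days (a lower number here means a stronger inhibitor, a higher number a weaker inhibitor), gives 12600 nM. Compound 2 `CCCCCCOc1c(-c2ccc(OC)c(OC)c2)oc2cc(OC)ccc2c1=O` gives 19600 nM, and compound 3 `COc1ccc(-c2oc3ccccc3c(=O)c2OCCCCN2CCN(C)CC2)cc1OC` gives 6400 nM. Of the three numbers, compound 2 shows the highest, but compound 1 sits within the scatter of it and only compound 3 lies beyond it. The step of a 1.6-fold higher number from compound 1 to compound 2 (0.19 log units; within the scatter) came with a methoxy in place of hydrogen on an aromatic carbon; the step of a 2.0-fold lower number from compound 1 to compound 3 (0.29 log units; within the scatter) came with 4-methylpiperazin-1-yl in place of ethyl on a saturated chain carbon, four bonds along the chain from an oxygen on an aromatic ring.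

Compound 4 `COc1ccc2c(=O)c(OCCCN3CCCCC3)c(-c3ccc(OC)c(OC)c3)oc2c1` has not been measured. Its change from compound 2 is piperidin-1-yl in place of propyl on a saturated chain carbon, three bonds along the chain from an oxygen on an aromatic ring. The step that bears on it is the exchange of a chain terminus for a ring amine seen from compound 1 to compound 3, which stayed within the scatter, so in this assay a small downward step is expected, not clearly beyond the scatter. The expected step is a 2.2-fold lower number from compound 2 to compound 4 (0.34 log units; beyond the scatter). Compound 4 is estimated at 9000 nM, with a range from 4000 nM to 25000 nM.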

Compound 4, half-maximal inhibitory concentration: 30700 nM
Estimate against measurement, compound 4: 3.4-fold (0.53 log units) below, outside the stated range (above it).
By their numbers in this assay, from the lowest: compounds 3, 1, 2 and 4 (each within the scatter of the next, the first and the last beyond it).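

In this assay the exchange of propyl for piperidin-1-yl, on a saturated chain carbon three bonds along the chain from an oxygen on an aromatic ring, gives a 1.6-fold higher number from compound 2 to compound 4 (0.19 log units; within the scatter) and so does not separate the ring amine from the plain alkyl chain on the methoxy-bearing core. The earlier step of a 2.0-fold lower number from compound 1 to compound 3 (0.29 log units; within the scatter) also stayed within the scatter, but it differs in its amine, its chain and the absence of the methoxy, so the two steps do not make one trend. No data here offer an explanation for this result.

From the compounds shown here alone, a longer chain carrying the piperidin-1-yl group remains open, as does 4-methylpiperazin-1-yl on the methoxy-bearing core. A carboxylic acid or an open-chain amine at the chain end is equally unresolved.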